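The source may hold more compounds than are shown below. What is called first, only, known or untested is meant among the compounds shown, and "the series" means these compounds.

Compound 3 `C#CCNC(=O)/C=C/c1cnc(Nc2ccc(C#N)cc2)nc1Oc1c(C)cc(C#N)cc1C` was tested in an ADME assay on TZM cells (Homo sapiens) for cytotoxicity, with a stated time of 1 days; on this read-out higher numbers stand for lower toxicity in this test and lower numbers for higher toxicity in this test. In this assay compound 3 gives only a limit, > 222 nM. Compound 1 `Cc1cc(C#N)cc(C)c1Oc1nc(Nc2ccc(C#N)cc2)ncc1/C=C/C(N)=O` also gives only a limit in this assay, > 243 nM. Compound 2 `Cc1cc(C#N)cc(C)c1Oc1nc(Nc2ccc(C#N)cc2)ncc1/C=C/C(=O)NC1CC1` likewise gives only a limit, > 221 nM. Every value is a limit, so the steps a step that the two limits leave unreadable from compound 1 to compound 2, a step that the two limits leave unreadable from compound 1 to compound 3 and a step that the two limits leave unreadable from compound 2 to compound 3 cannot be read, and compound 3 stands at the same kind of limit as the others with nothing to set it apart. Compound 4 `COCCNC(=O)/C=C/c1cnc(Nc2ccc(C#N)cc2)nc1Oc1c(C)cc(C#N)cc1C` differs from compound 3 by methoxymethyl in place of ethynyl on a saturated chain carbon bound to an amide-type nitrogen. Within the data shown here, none of the measured steps bears on this change in a readable way, as each rests on two limits. The expectation is that compound 4 again reaches a limit, with the step that the limit leaves unreadable from compound 3 to compound 4 expected to show no readable size. The estimated value for compound 4 is 250 nM, expected to lie between 150 nM and 600 nM.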

Compound 4, half-maximal cytotoxic concentration: > 213 nM
Compound 4 was reported as a limit; the forecaster's own chance of this, stated with the estimate: 85%; the middle value does not contradict the limit.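

In this assay compound 4 gives only a limit, > 213 nM. Its steps to compound 1, compound 2 and compound 3 therefore cannot be read, as those compounds also give only limits. The compounds shown leave open whether these groups on the amide-type nitrogen differ at all in this assay.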